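The compounds below may be only part of what the source reports. "The series", "measured", "known", "first", "only" and "open" are said of these compounds alone.

Working notes. Compound 1 `N=c1c2c(-c3ccccc3)cn(Cc3ccccc3)c2ncn1C1CCOCC1` in an ADME assay for permeability, using PAMPA, with a stated time of 30 min, at pH 7.4 (a lower number here means that the compound crosses the layer more slowly, a higher number that the compound crosses the layer faster), gives 1730 10^-6 cm/s. Compound 2 `COc1ccc(Cn2c(-c3ccccc3)c(-c3ccccc3)c3c(=N)n(CC4CCOCC4)cnc32)cc1` in this assay gives 1270 10^-6 cm/s; the numbers of compound 1 and compound 2 lie within the usual scatter of each other, so no order between them is read. Compound 3 `N=c1c2c(-c3ccccc3)cn(Cc3ccccc3)c2ncn1Cc1ccco1` is not yet measured. It differs from compound 1 by (furan-2-yl)methyl in place of oxan-4-yl on an aromatic nitrogen. For the measured compounds named here, no measured step covers this change; the expected step from compound 1 to compound 3 is a 1.1-fold lower number from compound 1 to compound 3 (0.03 log units; within the scatter), none beyond the scatter. Compound 3 is estimated at 1600 10^-6 cm/s, within 900 10^-6 cm/s to 2800 10^-6 cm/s.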

Compound 3, apparent permeability: 1740 10^-6 cm/s
Beside the measured number, compound 3's estimate is 1.1-fold (0.04 log units) below it; the measured number falls inside the stated range.
By their numbers in this assay, from the lowest: compounds 2, 1 and 3 (each within the scatter of the next).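

In this assay, for the compounds shown here, (furan-2-yl)methyl in place of oxan-4-yl on an aromatic nitrogen gives the first single-place step (a 1.0-fold higher number from compound 1 to compound 3 (0.00 log units; within the scatter)). At this position, then, a five-membered aromatic ring on a methyl link and a six-membered non-aromatic ring read alike. Nothing available accounts for this result.

Still open, from the compounds shown here alone, is whether an amine, a carboxylic acid or a longer chain on this nitrogen would also stay within the scatter. Also open, going by these compounds, is whether the same change reads alike on the core of compound 2.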